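The source may report more compounds than this note shows. Statements on the series, on what has been measured and on what is new or still open speak of the compounds shown alone.

Measured in an ADME assay on HEK293 cells (Homo sapiens) for cytotoxicity, read by resazurin assay, with a stated time of 48 h; on this read-out higher numbers stand for lower toxicity in this test and lower numbers for higher toxicity in this test:
compound 1 `O=S(=O)(Nc1ccc(-c2nc3ccccc3o2)cc1)c1cccs1`: > 100000 nM, a limit
compound 2 `Cc1ccccc1S(=O)(=O)Nc1ccc(-c2nc3ccccc3o2)cc1`: > 100000 nM, a limit
compound 3 `COc1ccc(Cl)cc1S(=O)(=O)Nc1ccc(-c2nc3ccccc3o2)cc1`: 75000 nM

For the measured compounds named here, compound 3 is the only measured compound with a true number, 75000 nM. Compound 1 and compound 2 both stop at the limit of > 100000 nM in this assay, at which 2 of the 3 values shown sit, which is a limit of the assay and not a number.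

Compound 4 `O=S(=O)(Nc1ccc(-c2nc3ccccc3o2)cc1)c1ccc(Cl)cc1` differs from compound 3 in one place, on the sulfonyl sulfur: 4-chlorophenyl in place of 5-chloro-2-methoxyphenyl on a sulfonyl sulfur. In words, 4-chlorophenyl stands in place of 5-chloro-2-methoxyphenyl.

Two measured steps end at the group that now leaves: an at least 1.3-fold lower number from compound 1 to compound 3 (0.12 log units; that floor lies within the scatter) and an at least 1.3-fold lower number from compound 2 to compound 3 (0.12 log units; that floor lies within the scatter). From the compounds shown here alone, both are only floors that lie within the scatter, so their true sizes remain open. The third step, a step that the two limits leave unreadable from compound 1 to compound 2, adds nothing to the size.

These steps give only weak guidance, and no large change is expected. Compound 3 at 75000 nM is the starting point, and the two floors suggest at most a modest drift towards higher numbers once its group is gone. The assay may well report only a limit for the new compound. The expected change is a 1.2-fold higher number from compound 3 to compound 4 (0.08 log units; within the scatter). For compound 4 the estimated value is 90000 nM, with an expected range of 45000 nM to 170000 nM.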

Compound 4, half-maximal cytotoxic concentration: > 100000 nM
Compound 4 ended at the assay's limit (the forecaster's own chance of this, stated with the estimate: 55%); middle value at least 1.1-fold (0.04 log units) away from the limit.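

In this assay, putting 4-chlorophenyl in place of 5-chloro-2-methoxyphenyl on the sulfonyl sulfur gives an at least 1.3-fold higher number from compound 3 to compound 4 (0.12 log units; that floor lies within the scatter), so this swap cannot be told apart from ordinary repeat variation on the evidence so far. Compound 4 keeps a chlorine on its phenyl ring and still gives only a limit, so among these compounds a chlorine alone does not bring a true number within the range of the test. The steps to compound 4 from compound 1 and from compound 2 join two limits and cannot be read, and the series now sits mostly at the ceiling of the test: the limit of > 100000 nM in this assay, at which 3 of the 4 values shown sit.

For the compounds shown here, with compound 3 as the only true number, the real size of its difference from the other three stays unknown, and so does whether any of these sulfonyl groups changes the reading at all. From the compounds shown here alone, it also stays open whether the methoxy group alone, as a 2-methoxyphenyl, or an amine or a carboxylic acid on the same phenyl ring would give a true number in this assay.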